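The source may report more compounds than this note shows. Statements on the series, on what has been measured and on what is new or still open speak of the compounds shown alone.

Going by the values given here, compound 2 `COc1cccc(C(=O)N(C)c2ccc3[nH]c(-c4n[nH]c5ccccc45)cc3n2)c1` gives the lower of the two numbers so far in a functional assay on KB cells (Homo sapiens) for antiproliferative activity, read by MTT assay, with a stated time of 72 h (on this read-out lower numbers stand for stronger inhibition and higher numbers for weaker inhibition), where compound 2 gives 9010 nM. Its nearest neighbour is compound 1 `CC(=O)N(C)c1ccc2[nH]c(-c3n[nH]c4ccccc34)cc2n1`, which in this assay gives 10300 nM; the two share the whole core and differ only at the carbonyl carbon, and the step of a 1.1-fold lower number from compound 1 to compound 2 (0.06 log units; within the scatter) lies within the scatter, so the two compounds cannot be ranked against each other.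

Compound 3 `Cc1ccc(S(=O)(=O)N(C)c2ccc3[nH]c(-c4n[nH]c5ccccc45)cc3n2)cc1` arises from compound 2 by (4-methylphenyl)sulfonyl in place of (3-methoxyphenyl)carbonyl on a nitrogen on an aromatic ring. Among the compounds with values here, the only measured step, a 1.1-fold lower number from compound 1 to compound 2 (0.06 log units; within the scatter), concerns a change on the carbonyl carbon while the carbonyl itself stayed in place, and it was within the scatter; no measured pair exchanges a carbonyl for a sulfonyl on the ring nitrogen, so the data give no direct guide for this change. Within the data shown here, since the one change seen at this position produced no step beyond the scatter, compound 3 is expected to stay near compound 2, with a step of a 1.1-fold lower number from compound 2 to compound 3 (0.03 log units; within the scatter). Compound 3 is therefore estimated at 8500 nM in this assay, with a range from 3000 nM to 25000 nM.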

Compound 3, half-maximal inhibitory concentration: 9500 nM
Estimate against measurement, compound 3: 1.1-fold (0.05 log units) below, within the range that was stated.
By their numbers in this assay, from the lowest: compounds 2, 3 and 1 (each within the scatter of the next).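

In this assay, replacing (3-methoxyphenyl)carbonyl with (4-methylphenyl)sulfonyl on a nitrogen on an aromatic ring gives a 1.1-fold higher number from compound 2 to compound 3 (0.02 log units; within the scatter), and replacing acetyl with (4-methylphenyl)sulfonyl at the same place gives a 1.1-fold lower number from compound 1 to compound 3 (0.04 log units; within the scatter). The earlier pair varied only what sits on the carbonyl carbon, whereas these steps exchange the carbonyl itself for a sulfonyl, and this exchange also gives no step beyond the scatter, so the three compounds cannot be ranked against one another. No measured evidence is available that bears on this result.

From the compounds shown here alone, all three groups at this place carry a carbonyl or a sulfonyl and leave the numbers within the scatter of each other, so it remains open whether this place would respond to a group of another kind, such as a plain hydrogen on that nitrogen, a simple alkyl chain or a chain ending in an amine or a carboxylic acid. The compounds shown also share the whole core and the methyl on that nitrogen, so they say nothing about how changes elsewhere would affect these numbers.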